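The compounds below may be only part of what the source reports. "The series", "measured", "known", "first", "only" and "open" are said of these compounds alone.

Measured compounds:
compound 1, `CC1=C(/C=C/C(=O)/C=C/c2ccc(Cl)cc2)C(C)(C)CCC1`, 33200 nM
compound 2, `COc1ccccc1/C=C/C(=O)/C=C/C1=C(C)CCCC1(C)C`, 88200 nM

In a functional assay on HeLa cells (Homo sapiens) for cytotoxicity, read by sulforhodamine B assay, with a stated time of 48 h (a higher number here means a weaker inhibitor, a lower number a stronger inhibitor), compound 1 gives 33200 nM, the lowest of the two numbers recorded. Its nearest neighbour is compound 2, which in this assay gives 88200 nM; the gap between these two values lies beyond the scatter, so compound 1 is the stronger of the pair as measured. The two structures differ in more than one place, so nothing about the weight of any single change can be read from them.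

Compound 3, `CC1=C(/C=C/C(=O)/C=C/c2cccnc2)C(C)(C)CCC1`, has not been measured. It keeps the core of compound 1 and differs from it in one place: pyridin-3-yl in place of 4-chlorophenyl on a double-bonded chain carbon bound to a double-bonded chain carbon. Within the data shown here, no step of this kind between measured compounds is available, so the expectation rests on compound 1 alone. Compound 3 is expected to give a number somewhat higher than that of compound 1, a step of a 1.7-fold higher number from compound 1 to compound 3 (0.22 log units; within the scatter), though one that may well stay within the scatter. The estimate for compound 3 in this assay is 55000 nM, with a range from 20000 nM to 150000 nM.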

Compound 3, half-maximal inhibitory concentration: 17400 nM
For compound 3 the middle estimate is 3.2-fold (0.50 log units) above the measured one; the measured number lies below the stated range.
By their numbers in this assay, from the lowest: compounds 3 and 1 (each within the scatter of the next); then compound 2.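

In this assay the piece now holds a step that changes one place only, and it reads a 1.9-fold lower number from compound 1 to compound 3 (0.28 log units; within the scatter) and so lies within the scatter. At this position, on a double-bonded chain carbon bound to a double-bonded chain carbon, pyridin-3-yl, a ring with 1 hetero atom and 1 hydrogen-bond acceptor, can thus stand in place of 4-chlorophenyl, a ring of carbon only that carries chlorine, without a difference that the assay can separate from repeat variation. No measurement of any property of these groups is at hand to account for this outcome.

A single step cannot show whether the position is equally undemanding for other groups, such as an aminomethyl group, a carboxylic acid, pyridin-2-yl or an unsubstituted phenyl ring, so the reach of this result remains undefined. It also leaves open whether the same exchange would read alike on a different core or in a cell line other than HeLa.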